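From compound 3 to compound 4 in the series

The source may hold more compounds than are shown below. What is called first, only, known or untested is meant among the compounds shown, and "the series" means these compounds.

compound 1 `O=C1CC(c2ccccc2OCc2ccc(F)cc2)Oc2ccccc21` gives 28200 nM
compound 2 `CC(C)COc1ccccc1C1CC(=O)c2ccccc2O1` gives 36700 nM
compound 3 `CC(C)=CCOc1ccccc1C1CC(=O)c2ccccc2O1` gives 32700 nM

In a functional assay on RAW264.7 cells (Mus musculus) for inhibition, read by Griess assay, with stated times of 1 h and 24 h (a lower number here means a stronger inhibitor, a higher number a weaker inhibitor), compound 3 stands at 32700 nM and lies within the scatter of the other two values. Compound 4 `COc1ccccc1C1CC(=O)c2ccccc2O1` follows by hydrogen in place of 2-methylprop-1-en-1-yl on a saturated chain carbon bound to an oxygen on an aromatic ring and so has hydrogen in place of 2-methylprop-1-en-1-yl on a saturated chain carbon bound to an oxygen on an aromatic ring. Three measured steps at this place bear on it: a 1.3-fold higher number from compound 1 to compound 2 (0.11 log units; within the scatter) and a 1.2-fold higher number from compound 1 to compound 3 (0.06 log units; within the scatter) and a 1.1-fold lower number from compound 2 to compound 3 (0.05 log units; within the scatter) all stay within the scatter. None of them reaches hydrogen, so the support is indirect. No step beyond the scatter is expected in this assay on this evidence. The expected step is a 1.1-fold higher number from compound 3 to compound 4 (0.03 log units; within the scatter) here. Compound 4 is expected at 35000 nM with 15000 nM to 80000 nM as the estimated range.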

Compound 4, half-maximal inhibitory concentration: 47300 nM
Estimate against measurement, compound 4: 1.4-fold (0.13 log units) below; the range from low to high includes it.
By their numbers in this assay, from the lowest: compounds 1, 3, 2 and 4 (each within the scatter of the next).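

In this assay, methoxy in compound 4 stays within the scatter of all three other groups (a 1.4-fold higher number from compound 3 to compound 4 (0.16 log units; within the scatter)) and (a 1.3-fold higher number from compound 2 to compound 4 (0.11 log units; within the scatter)) and (a 1.7-fold higher number from compound 1 to compound 4 (0.22 log units; within the scatter)). The group on this oxygen can therefore be as small as methyl without a step beyond the scatter, so the read-out shows no dependence on this group across compounds 1 to 4. Nothing at hand bears on this result.

Going by these compounds, whether an amine or a carboxylic acid on a longer chain at this oxygen gives a step beyond the scatter remains open. On these data alone, a free hydroxyl in place of methoxy is equally open.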